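The source may report more compounds than this note shows. Statements on the series, on what has been measured and on what is new or still open speak of the compounds shown alone.

Compound 2 `CSc1ccc(NC(=O)N[C@H]2CC[C@H](Oc3ccc(F)cc3)CC2)cc1` is the starting point here. In a functional assay on CRL2813 cells (Homo sapiens) for cytotoxicity, read by sulforhodamine B assay, with a stated time of 5 days (a lower number here means a stronger inhibitor, a higher number a weaker inhibitor), compound 2 gives only a limit of the assay, > 20000 nM. Compound 1 `CSc1ccccc1NC(=O)N[C@H]1CC[C@H](Oc2ccc(F)cc2)CC1` likewise gives only a limit, > 20000 nM. The step that the two limits leave unreadable from compound 1 to compound 2 is therefore unreadable, since both values sit at the limit of > 20000 nM in this assay, at which 2 of the 2 values shown sit. Compound 3 `Cc1cccc(NC(=O)N[C@H]2CC[C@H](Oc3ccc(F)cc3)CC2)c1` differs from compound 2 by 3-methylphenyl in place of 4-(methylsulfanyl)phenyl on an amide-type nitrogen. Going by the values given here, no measured step bears on this change, so no shift beyond the scatter in this assay is expected. The step that the limit leaves unreadable from compound 2 to compound 3 is the estimated one. Compound 3 is expected to give 25000 nM, with a range from 8000 nM to 80000 nM.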

Compound 3, half-maximal inhibitory concentration: 14400 nM
Beside the measured number, compound 3's estimate is 1.7-fold (0.24 log units) above it, and the stated range covers the measured number.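

Compound 3 gives a readable number in this assay, 14400 nM, so this place on the amide-type nitrogen can now be compared on a scale: the limit of > 20000 nM in this assay, at which 2 of the 3 values shown sit.

The change to 3-methylphenyl gives an at least 1.3-fold lower number from compound 2 to compound 3 (0.14 log units; that floor lies within the scatter) and an at least 1.3-fold lower number from compound 1 to compound 3 (0.14 log units; that floor lies within the scatter). From the compounds shown here alone, both steps are only floors, so the true size of the change remains unknown, and neither floor shows a shift beyond the scatter.

Going by these compounds, it remains open whether an amine or a carboxylic acid on the phenyl ring, or a longer chain in place of the methyl, would move the number beyond the scatter.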